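The compounds below may be only part of what the source reports. "The series", "measured", "known", "first", "only" and "open" are said of these compounds alone.

Compound 1 `CCOC(=O)/C=C/C(=O)N(CC(N)=O)NC(=O)[C@@H]1CCCN1C(C)=O` gives 8.3 nM in an assay on isolated protein for inhibition of legumain (Mus musculus), read by fluorescence, with stated times of 30 s and 2.5 h; on this read-out higher numbers stand for weaker inhibition and lower numbers for stronger inhibition.
Compound 2 `CCOC(=O)/C=C/C(=O)N(CC(N)=O)NC(=O)[C@@H]1CCCN1C(=O)C(C)(C)NC(C)=O` gives 198 nM.
Compound 3 `CCOC(=O)C1OC1C(=O)N(CC(N)=O)NC(=O)[C@@H]1CCCN1C(=O)C1(NC(C)=O)CC1` gives 4.4 nM.

Compound 3 has the lowest of the three numbers, though compound 1 lies within the scatter of it; only compound 2 stands clearly higher. Compound 4 `CCOC(=O)/C=C/C(=O)N(CC(N)=O)NC(=O)[C@@H]1CCCN1C(=O)C1(NC(C)=O)CC1` differs from compound 3 in one place: a group of 7 heavy atoms (5 carbon, 2 oxygen; no ring) in place of a group of 8 heavy atoms (5 carbon, 3 oxygen; one three-membered non-aromatic ring with 1 hetero atom), on a carbonyl carbon. Among the compounds with values here, no measured step makes exactly this swap. Within the data shown here, the single measured step, a 24-fold higher number from compound 1 to compound 2 (1.38 log units; beyond the scatter), alters the other carbonyl cap and shows that changes there can move the number a great deal. Compound 1 carries the same 2-(ethoxycarbonyl)ethenyl group as compound 4 and sits within the scatter of compound 3, so only a modest shift is expected. Compound 4 is therefore estimated at 15 nM (range 4 nM to 80 nM), an expected step of a 3.4-fold higher number from compound 3 to compound 4 (0.53 log units; beyond the scatter).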

Compound 4, half-maximal inhibitory concentration: 9.3 nM
Estimate against measurement, compound 4: 1.6-fold (0.21 log units) above; the measured number falls inside the stated range.
By their numbers in this assay, from the lowest: compounds 3, 1 and 4 (each within the scatter of the next, the first and the last beyond it); then compound 2.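

In this assay, 2-(ethoxycarbonyl)ethenyl in place of the three-membered ring group on a carbonyl carbon brings a 2.1-fold higher number from compound 3 to compound 4 (0.33 log units; beyond the scatter), so this swap has only a modest effect. On the other carbonyl carbon, 1-acetamidocyclopropyl in place of 1-acetamido-1-methylethyl brings a 21-fold lower number from compound 2 to compound 4 (1.33 log units; beyond the scatter), whereas in place of methyl it brings a 1.1-fold higher number from compound 1 to compound 4 (0.05 log units; within the scatter), so only 1-acetamido-1-methylethyl stands clearly apart. No evidence here explains these steps. As far as these compounds go, what remains open is whether a carboxylic acid in place of the ethyl ester, or 1-acetamidocyclobutyl on the other carbonyl carbon, would keep the number low.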